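This account rests on a few compounds, and the source may have more. Where it says the series, first, only, none or still open, it means among the compounds named here.

Measured so far:
Compound 1, `CN(C)CCCNc1nc(-c2ccc(NC(=O)Nc3ccccc3F)cc2)nc2ccsc12`: in a functional assay on MKN-45 cells (Homo sapiens) for cytotoxicity, read by MTT assay, with a stated time of 72 h (a higher number here means a weaker inhibitor, a lower number a stronger inhibitor), compound 1 gives 730 nM.
Compound 2, `CN(C)CCCNc1nc(-c2ccc(NC(=O)Nc3ccccc3Cl)cc2)nc2ccsc12`: in this assay compound 2 gives 690 nM.
Compound 3, `CN(C)CCNc1nc(-c2ccc(NC(=O)Nc3ccc(F)cc3)cc2)nc2c(Cl)c(Cl)sc12`: in this assay compound 3 gives 1350 nM.

The three numbers lie within the usual scatter of one another, so no order among them can be read from these data. Compound 4, `CN(C)CCNc1nc(-c2ccc(NC(=O)Nc3ccc(Cl)cc3)cc2)nc2c(Cl)c(Cl)sc12`, has not yet been measured. It differs from compound 3 by chloro in place of fluoro on an aromatic carbon. The same kind of change was already made from compound 1 to compound 2, where it reads (chloro in place of fluoro on an aromatic carbon); the two places are not the same, the earlier one being ortho to a large group and the new one para to a large group. The step it made there was a 1.1-fold lower number from compound 1 to compound 2 (0.02 log units; within the scatter). How the core of compound 3 differs from the core of compound 1 is not broken down here.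

Compound 4 is expected to give about 1200 nM, between 500 nM and 2800 nM, because the step of a 1.1-fold lower number from compound 1 to compound 2 (0.02 log units; within the scatter) stayed within the scatter. The estimated step from compound 3 to compound 4 is therefore a 1.1-fold lower number from compound 3 to compound 4 (0.05 log units; within the scatter), resting only on that earlier pair.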

Compound 4, half-maximal inhibitory concentration: 910 nM
For compound 4 the middle estimate is 1.3-fold (0.12 log units) above the measured one; the measured number falls inside the stated range.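

In this assay, chloro in place of fluoro on an aromatic carbon, para to a large group, gives a 1.5-fold lower number from compound 3 to compound 4 (0.17 log units; within the scatter), so no change in activity can be read from this pair. Set beside the earlier pair on the other core, the step does not read differently, and in that limited sense the swap behaves alike on both cores: the same change on two cores in this assay, a 1.1-fold lower number (0.02 log units; within the scatter) from compound 1 to compound 2 and a 1.5-fold lower number (0.17 log units; within the scatter) from compound 3 to compound 4, 1.4-fold (0.15 log units) apart, within the scatter of two such steps. This does not show that the change carries over in general, since neither step stands clear of the scatter, only two pairs are shown, and the two pairs differ in the place of the halogen as well as in their cores.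

The compounds shown leave open whether a methoxy or trifluoromethyl group at this place on the phenyl ring would give a step that can be read on either core. They also leave open whether a morpholine in place of the dimethylamino group would alter how such a step carries from one core to the other.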